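Exchanging hydroxy and methoxy positions from compound 2 to compound 3

The source may report more compounds than this note shows. Statements on the series, on what has been measured and on what is new or still open speak of the compounds shown alone.

In a functional assay on MDA-MB-231 cells (Homo sapiens) for cytotoxicity, read by MTT assay, with a stated time of 48 h (on this read-out lower numbers stand for stronger inhibition and higher numbers for weaker inhibition), compound 2 `COc1ccc(C2=NOC(COc3ccc(-c4nnnn4-c4cc(OC)c(OC)c(OC)c4)cc3N)C2)cc1O` gives 3380 nM, level within the scatter with compound 1 `COc1cc(C2=NOC(COc3ccc(-c4nnnn4-c4cc(OC)c(OC)c(OC)c4)cc3N)C2)cc(OC)c1OC` at 3230 nM. Compound 3 `COc1cc(C2=NOC(COc3ccc(-c4nnnn4-c4cc(OC)c(OC)c(OC)c4)cc3N)C2)ccc1O` carries 4-hydroxy-3-methoxyphenyl in place of 3-hydroxy-4-methoxyphenyl on a carbon with a double bond to nitrogen. Among the measured compounds shown here, the only measured step at this place, a 1.0-fold higher number from compound 1 to compound 2 (0.02 log units; within the scatter), exchanged a different pair of groups and stayed within the scatter. It offers no reason to expect a real shift in this assay. The expected change is a 1.0-fold higher number from compound 2 to compound 3 (0.02 log units; within the scatter), with no direction beyond the scatter. For compound 3 the estimated value is 3500 nM, with an expected range of 1400 nM to 9000 nM.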

Compound 3, half-maximal inhibitory concentration: 3620 nM
Estimate against measurement, compound 3: 1.0-fold (0.01 log units) below; low and high end bracket the measured number.
By their numbers in this assay, from the lowest: compounds 1, 2 and 3 (each within the scatter of the next).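

In this assay, exchanging the hydroxy and methoxy positions gives (a 1.1-fold higher number from compound 2 to compound 3 (0.03 log units; within the scatter)), so 3-hydroxy-4-methoxyphenyl and 4-hydroxy-3-methoxyphenyl cannot be told apart at this place. The step from 3,4,5-trimethoxyphenyl to 4-hydroxy-3-methoxyphenyl, (a 1.1-fold higher number from compound 1 to compound 3 (0.05 log units; within the scatter)), is equally small, so all three groups on the carbon with a double bond to nitrogen read alike here. Nothing measured explains this result. The compounds shown leave open whether an amine or a carboxylic acid on this aromatic ring would give a number beyond the scatter.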